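Metabolic stability along a series of sulfonyl pyrrolidines

The compounds below may be only part of what the source reports. "The series", "measured", "known", "first", "only" and "open" are said of these compounds alone.

This account follows a series of amides built on a shared core and read in an ADME assay on microsomes from liver (Homo sapiens) for metabolic stability, with a stated time of 10 min; on this read-out higher numbers stand for a more stable compound and lower numbers for a less stable compound. Compound 1 `O=C(O)C12CCC(C(=O)N3CC[C@](c4ccc(C(F)(C(F)(F)F)C(F)(F)F)cc4)(S(=O)(=O)c4ccc(F)cc4)C3)(CC1)C2` is recorded in this assay as "not determined" (no result reported). Compound 2 `O=C(O)C12CCC(C(=O)N3CC[C@](c4ccc(C(F)(C(F)(F)F)C(F)(F)F)cc4)(S(=O)(=O)c4ccc(F)cc4)C3)(CC1)CC2` gives 100% in this assay. Compound 3 `O=C([C@H]1CC[C@H](c2nnn[nH]2)CC1)N1CC[C@](c2ccc(C(F)(C(F)(F)F)C(F)(F)F)cc2)(S(=O)(=O)c2ccc(F)cc2)C1` gives 100% in this assay, so compound 3 stands level with compound 2, the step of no change at the digits printed from compound 2 to compound 3 (within the scatter) lying within the scatter; compound 1 offers nothing to compare with. The next compound, compound 4 `O=C(N1CC[C@](c2ccc(C(F)(C(F)(F)F)C(F)(F)F)cc2)(S(=O)(=O)c2ccc(F)cc2)C1)C1(CO)CCS(=O)(=O)CC1`, differs from compound 3 in one place: 4-(hydroxymethyl)-1,1-dioxothian-4-yl in place of 4-(1H-tetrazol-5-yl)cyclohexyl on a carbonyl carbon. Going by the values given here, the only step measured so far, no change at the digits printed from compound 2 to compound 3 (within the scatter), exchanged a group of similar size on the same carbonyl carbon and left the read-out unchanged, which is the sole guide here, and the group that enters in compound 4 has no counterpart among the measured compounds. Compound 4 is therefore expected to sit near the top of the scale, with a step of about a number 8 percentage points lower from compound 3 to compound 4 (within the scatter) from compound 3, and its estimated value is 92% with a range from 70% to 100%.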

Compound 4, percent of the compound remaining: 75%
Beside the measured number, compound 4's estimate is 17 percentage points above it, within the range that was stated.
By their numbers in this assay, from the lowest: compound 4; then compounds 2 and 3 (each within the scatter of the next).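

In this assay, going by these compounds alone, this position, on a carbonyl carbon whose other neighbours are an amide-type nitrogen in a ring, proves sensitive to the group it carries: with 4-(hydroxymethyl)-1,1-dioxothian-4-yl in place of 4-(1H-tetrazol-5-yl)cyclohexyl, the read-out shows a number 25 percentage points lower from compound 3 to compound 4 (beyond the scatter) and so moves beyond the scatter for the first time in this account. The comparison with the other fully measured amide agrees, with a number 25 percentage points lower from compound 2 to compound 4 (beyond the scatter) on exchange of its group for the same 4-(hydroxymethyl)-1,1-dioxothian-4-yl. No measurement at hand explains this drop. The compounds shown do not separate the part played by the hydroxymethyl from that of the 1,1-dioxothian ring, as the two enter together. On these data alone, it also remains open how a carboxylic acid or an amine in place of the hydroxymethyl on that ring would read.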